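This account rests on a few compounds, and the source may have more. Where it says the series, first, only, none or still open, it means among the compounds named here.

Compound 1 `C=C1C[C@]23C[C@@]1(O)CC[C@H]2c1ccc(OS(=O)(=O)c2ccc(C)cc2)c(C)c1[C@@H]3Cn1cc(-c2ccc(OC)cc2)nn1` is the tosylate whose cytotoxicity was tested in a functional assay on HL-60 cells (Homo sapiens) for cytotoxicity, read by MTT assay, with a stated time of 4 days; on this read-out higher numbers stand for weaker inhibition and lower numbers for stronger inhibition. In this assay compound 1 gives only a limit, > 20000 nM. Its phenol partner, compound 2 `C=C1C[C@]23C[C@@]1(O)CC[C@H]2c1ccc(O)c(C)c1[C@@H]3Cn1cc(-c2ccc(OC)cc2)nn1`, likewise gives only a limit in this assay, > 20000 nM. Among the compounds with values here, the one measured step, a step that the two limits leave unreadable from compound 1 to compound 2, is therefore unreadable, and the limit of > 20000 nM in this assay, at which 2 of the 2 values shown sit, is all the data offer. Compound 3 `C=C1C[C@]23C[C@@]1(O)CC[C@H]2c1ccc(OS(=O)(=O)c2ccc(C)cc2)c(C)c1[C@@H]3Cn1cc(-c2ccccn2)nn1` differs from compound 1 by pyridin-2-yl in place of 4-methoxyphenyl on an aromatic carbon. With no readable step to lean on, and compound 1 at > 20000 nM, the author expects compound 3 to remain at the limit as well, a step that the limit leaves unreadable from compound 1 to compound 3, estimated at 30000 nM within 10000 nM to 100000 nM.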

Compound 3, half-maximal inhibitory concentration: > 20000 nM
Compound 3: a limit, no number; the forecaster's own chance of this, stated with the estimate: 85%; the middle value does not contradict the limit.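

Compound 1 and compound 3 both give only a limit, so no step can be read between them: the limit of > 20000 nM in this assay, at which 3 of the 3 values shown sit. The compounds shown leave open whether either group change alters cytotoxicity in this assay.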